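A few compounds are considered here, and "the series" means these few. Any claim that something is new, unique, unknown or untested is made for them only; others in the source may bear on it.

Compound 1 `COc1ccc(C(=O)Nc2cccc(-c3oc4cc(-c5ccc(F)cc5)ccc4c(=O)c3O)c2)cc1`: 5490 nM
Compound 2 `O=C(Nc1cccc(-c2oc3cc(-c4ccc(F)cc4)ccc3c(=O)c2O)c1)c1ccc(Cl)cc1`: 4030 nM

In a functional assay on HCC1937 cells (Homo sapiens) for antiproliferative activity, read by CCK-8 assay, with a stated time of 72 h (a higher number here means a weaker inhibitor, a lower number a stronger inhibitor), compound 2 gives 4030 nM and compound 1 gives 5490 nM; the step of a 1.4-fold lower number from compound 1 to compound 2 (0.13 log units; within the scatter) leaves the two numbers within the scatter of each other. Compound 3 `COc1ccccc1C(=O)Nc1cccc(-c2oc3cc(-c4ccc(F)cc4)ccc3c(=O)c2O)c1` differs from compound 2 by 2-methoxyphenyl in place of 4-chlorophenyl on a carbonyl carbon. Going by the values given here, the only measured step that bears on this position, from compound 1 to compound 2, was small, and no measured compound carries the 2-methoxyphenyl group. Compound 3 is therefore expected to stay close to compound 2, with a 1.2-fold higher number from compound 2 to compound 3 (0.09 log units; within the scatter) and an estimated 5000 nM, in the range 2500 nM to 10000 nM.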

Compound 3, half-maximal inhibitory concentration: 9050 nM
Estimate against measurement, compound 3: 1.8-fold (0.26 log units) below; the measured number falls inside the stated range.
By their numbers in this assay, from the lowest: compounds 2, 1 and 3 (each within the scatter of the next, the first and the last beyond it).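

In this assay, this position on the carbonyl carbon now gives a step beyond the scatter, though a modest one: a 2.2-fold higher number from compound 2 to compound 3 (0.35 log units; beyond the scatter), with 2-methoxyphenyl in place of 4-chlorophenyl. Yet that change alters both the group and where it sits, and with the group held as methoxy, a 1.6-fold higher number from compound 1 to compound 3 (0.22 log units; within the scatter), which stays within the scatter and so does not separate 2-methoxyphenyl from 4-methoxyphenyl. Nothing available explains either step. Still open, going by these compounds, is whether 2-chlorophenyl would follow 4-chlorophenyl or 2-methoxyphenyl here. Also open, on these data alone, is how a pyridine ring or a cyclohexyl group would fare on this carbonyl.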